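Trifluoromethyl to hydroxymethyl at the clearance limit

A few compounds are considered here, and "the series" means these few. Any claim that something is new, unique, unknown or untested is made for them only; others in the source may bear on it.

In an ADME assay (liver) for metabolic stability, with Liver microsome (Rattus norvegicus) as the target, using microsomes and NADPH, with a stated time of 30 min, at 37 degrees C, tested at 1 uM (on this read-out lower numbers stand for slow clearance and higher numbers for fast clearance), compound 3 `CC(O)(c1ccc(-c2ncc(S(=O)(=O)c3ccc(N)nc3)s2)c(Cl)c1)C(F)(F)F` gives < 14 mL.min-1.g-1 as a limit of the assay and not a number. Compound 3 therefore sits at the limit of < 14 mL.min-1.g-1 in this assay, at which 1 of the 3 values shown sits, and has no exact value. Compound 1 `CC(C)Nc1nc(S(=O)(=O)c2ccc(N)nc2)ccc1-c1ccc(C(C)(O)C(F)(F)F)cn1` stands at 62 mL.min-1.g-1 and compound 2 `CC(O)(c1ccc(-c2ccc(S(=O)(=O)c3ccc(N)nc3)nc2Oc2ccccc2)nc1)C(F)(F)F` at 213 mL.min-1.g-1 on the same scale. Going by the values given here, the one measured step of a 3.4-fold higher number from compound 1 to compound 2 (0.54 log units; beyond the scatter) is a different change and bears only loosely on what follows. Compound 4 `CC(O)(CO)c1ccc(-c2ncc(S(=O)(=O)c3ccc(N)nc3)s2)c(Cl)c1` brings hydroxymethyl in place of trifluoromethyl on a saturated chain carbon bound to an aromatic carbon, an oxygen on a saturated carbon and a saturated chain carbon as its difference from compound 3, with hydroxymethyl in place of trifluoromethyl on a saturated chain carbon bound to an aromatic carbon, an oxygen on a saturated carbon and a saturated chain carbon. Among the compounds with values here, no measured step tests this change. In this assay the estimated step is a number no lower from compound 3 to compound 4 (the limit leaves the size open) and is expected to be small, with none beyond the scatter the likeliest outcome. Compound 4 is expected near 14 mL.min-1.g-1 within a range of 7 mL.min-1.g-1 to 32 mL.min-1.g-1 on this scale.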

Compound 4, intrinsic clearance in microsomes: < 14 mL.min-1.g-1
Compound 4 ended at the assay's limit (the forecaster's own chance of this, stated with the estimate: 50%); the middle value lies on the limit itself.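

In this assay, going by these compounds alone, compound 3 and compound 4 both end at a limit of the assay, not at a number, so no step between them can be read: the limit of < 14 mL.min-1.g-1 in this assay, at which 2 of the 4 values shown sit. From the compounds shown here alone, whether hydroxymethyl in place of trifluoromethyl changes clearance at all remains open.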